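The source may hold more compounds than are shown below. What is called first, only, known or untested is meant among the compounds shown, and "the series" means these compounds.

Measured compounds:
compound 1, `NC(=O)c1c(NC(=O)c2ccccc2C(F)(F)F)sc2c1CCN(C(=S)Nc1ccccc1Cl)C2`: 17600 nM
compound 2, `Cc1ccccc1C(=O)Nc1sc2c(c1C(N)=O)CCN(C(=S)Nc1ccccc1Cl)C2`: 20900 nM
compound 3, `Cc1ccccc1C(=O)Nc1sc2c(c1C(N)=O)CCN(C(=S)Nc1ccccc1C(F)(F)F)C2`: 23200 nM

All three were tested in a functional assay on HL-60 cells (Homo sapiens) for antiproliferative activity, with a stated time of 24 h; on this read-out higher numbers stand for weaker inhibition and lower numbers for stronger inhibition. Compound 1 carries a trifluoromethyl group on the aryl amide and a chloro group on the aryl thiourea; compound 2 keeps the chloro group but has a methyl group on the aryl amide; compound 3 has methyl on the aryl amide and trifluoromethyl on the aryl thiourea. The change from compound 1 to compound 2 is methyl in place of trifluoromethyl on an aromatic carbon, and it gave a 1.2-fold higher number from compound 1 to compound 2 (0.07 log units; within the scatter). The change from compound 2 to compound 3 gave a 1.1-fold higher number from compound 2 to compound 3 (0.05 log units; within the scatter). Compound 3 gives the highest of the three numbers, but every gap to the others lies within the scatter, so no ranking among them can be drawn. The difference between the cores of compound 1 and compound 3 is not broken down here.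

Compound 4, `Cc1ccccc1NC(=S)N1CCc2c(sc(NC(=O)c3ccccc3C)c2C(N)=O)C1`, has not been measured in this assay. It arises from compound 3 by methyl in place of trifluoromethyl on an aromatic carbon. The description of the place matches that of the change from compound 1 to compound 2 word for word, so this is the same change, made here on the aryl thiourea rather than the aryl amide. Because that earlier step measured a 1.2-fold higher number from compound 1 to compound 2 (0.07 log units; within the scatter), a step of similar size is expected here, a 1.1-fold higher number from compound 3 to compound 4 (0.05 log units; within the scatter). On this basis compound 4 is estimated at 26000 nM in this assay, with a likely range from 13000 nM to 52000 nM.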

Compound 4, half-maximal inhibitory concentration: > 50000 nM
Compound 4: no number, only a limit; the forecaster's own chance of this, stated with the estimate: 15%; middle value at least 1.9-fold (0.28 log units) away from the limit.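

In this assay compound 4 gives > 50000 nM, which is a limit of the assay and not a number. Read against that limit, methyl in place of trifluoromethyl on the aryl thiourea gives an at least 2.1-fold higher number from compound 3 to compound 4 (0.33 log units; beyond the scatter), and methyl in place of chloro on the same aryl thiourea gives an at least 2.3-fold higher number from compound 2 to compound 4 (0.37 log units; beyond the scatter), so both steps lie beyond the scatter, but their full size stays unknown. This shows that the change that left the number within the scatter on the aryl amide does not do so on the aryl thiourea, yet it does not show that the size of the change itself depends on where it is made or on the core that carries it: the same change on two cores in this assay, a 1.2-fold higher number (0.07 log units; within the scatter) from compound 1 to compound 2 and an at least 2.1-fold higher number (0.33 log units; beyond the scatter) from compound 3 to compound 4; the limit leaves it open whether they differ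

All the aryl groups shown carry only methyl, chloro or trifluoromethyl, so it remains open how an amine, a carboxylic acid or a longer chain in their place would read in this assay. The shown compounds also leave open how far the methyl compound lies beyond its limit, and whether any change to the carboxamide or the thiourea would alter these numbers.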